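The source may hold more compounds than are shown below. What is called first, only, known or untested is meant among the compounds shown, and "the series" means these compounds.

Compound 1 `CN(C)c1cc2[nH]c(C3CCCCC3)nc2cc1NC(=O)c1ccccc1` was examined in an ADME assay on Vero cells (Chlorocebus sabaeus) for cytotoxicity, read by resazurin assay, with a stated time of 3 days; on this read-out higher numbers stand for weaker inhibition and lower numbers for stronger inhibition. In this assay compound 1 gives > 100 ug/mL, which is a limit of the assay rather than a number. Compound 2 `CCN(CC)c1cc2[nH]c(C3CCCCC3)nc2cc1NC(=O)OCCOCCOC` in this assay likewise gives > 100 ug/mL, again only a limit. Both known values therefore share (the limit of > 100 ug/mL in this assay, at which 2 of the 2 values shown sit). Compound 3 `CN(C)c1cc2[nH]c(C3CCCCC3)nc2cc1NC(=O)c1cccs1` has not yet been measured; it differs from compound 1 by thiophen-2-yl in place of phenyl on a carbonyl carbon. With both known values sitting at a limit, the step that the limit leaves unreadable from compound 1 to compound 3 is expected to be none beyond the usual scatter in this assay. Compound 3 is accordingly expected to give 150 ug/mL, within a range of 60 ug/mL to 400 ug/mL.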

Compound 3, half-maximal inhibitory concentration: > 100 ug/mL
Compound 3: only a limit was reported; the forecaster's own chance of this, stated with the estimate: 85%; the middle value lies beyond the limit too.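

No step can be read from compound 1 to compound 3 in this assay: both values are limits, not numbers. The compounds shown leave open whether thiophen-2-yl in place of phenyl on a carbonyl carbon shifts the read-out at all.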